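The source may hold more compounds than are shown below. What is called first, only, known or untested is meant among the compounds shown, and "the series" means these compounds.

Compound 1, `Cc1cc(S(N)(=O)=O)ccc1NC(=O)COc1ccc(F)cc1Oc1cc2ccccc2cc1C`, in an ADME assay on C8166 cells (Homo sapiens) for cytotoxicity, read by MTT assay; on this read-out lower numbers stand for higher toxicity in this test and higher numbers for lower toxicity in this test: 66900 nM
Compound 2, `Cc1cc(S(N)(=O)=O)ccc1NC(=O)COc1ccc(F)cc1Oc1ccc2ccccc2c1Cl`: 47100 nM

Of the two numbers in this assay, compound 2 sits at the lower end, but the gap to compound 1, a 1.4-fold lower number from compound 1 to compound 2 (0.15 log units; within the scatter), is within the scatter, so the two compounds cannot be told apart on this read-out.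

The next compound, compound 3, `Cc1cc(S(N)(=O)=O)ccc1NC(=O)COc1ccc(F)cc1Oc1ccc2cccc(F)c2c1`, differs from compound 2 in one place: 8-fluoronaphthalen-2-yl in place of 1-chloronaphthalen-2-yl on an oxygen on an aromatic ring. The shared core and the fluorophenyl ether are left untouched; only the group on the oxygen on the aromatic ring, whose other neighbour is an aromatic carbon, is exchanged for another naphthyl bearing a different halogen.

For the measured compounds named here, one measured step bears on this change. It is the swap of one naphthyl for another on the same oxygen, from compound 1 to compound 2, which gave a 1.4-fold lower number from compound 1 to compound 2 (0.15 log units; within the scatter). Since that exchange left the number within the scatter, a further naphthyl exchange at the same place is expected to do the same in this assay.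

For compound 3 the estimated value in this assay is 50000 nM, between 25000 nM and 100000 nM, an expected step of a 1.1-fold higher number from compound 2 to compound 3 (0.03 log units; within the scatter).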

Compound 3, half-maximal cytotoxic concentration: 171000 nM
Beside the measured number, compound 3's estimate is 3.4-fold (0.53 log units) below it, outside the stated range (above it).
By their numbers in this assay, from the lowest: compounds 2 and 1 (each within the scatter of the next); then compound 3.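

In this assay, the group on the oxygen on the aromatic ring now separates the compounds. 8-fluoronaphthalen-2-yl in place of 1-chloronaphthalen-2-yl gives a 3.6-fold higher number from compound 2 to compound 3 (0.56 log units; beyond the scatter), and in place of 3-methylnaphthalen-2-yl it gives a 2.6-fold higher number from compound 1 to compound 3 (0.41 log units; beyond the scatter); both steps are modest but beyond the scatter, whereas the earlier exchange of one naphthyl group for another showed no readable difference. This place is therefore not indifferent to which substituted naphthyl group it carries, although the data offer no measured explanation for the higher number.

The step from 1-chloronaphthalen-2-yl to 8-fluoronaphthalen-2-yl changes both the halogen and where it sits on the naphthyl group, so the compounds shown cannot say which of these two differences matters, or whether the absence of chlorine alone would be enough. Going by these compounds, it also remains open how a naphthyl group carrying an amine or a carboxylic acid at this place would read in this assay.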